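Amino for methoxycarbonyl on the aryl amide

The source may hold more compounds than are shown below. What is called first, only, known or untested is meant among the compounds shown, and "the series" means these compounds.

Compound 3 `COC(=O)c1ccc(C(=O)Nc2cccc(NC(=O)COc3ccc4c(=O)ccoc4c3)c2)cc1` is measured in an assay on isolated protein for inhibition of Rho-associated protein kinase 2 (Homo sapiens), read by scintillation counting, radiometric assay and 33P incorporation, with a stated time of 40 min, in the presence of a further agent that is not named here (a lower number here means a stronger inhibitor, a higher number a weaker inhibitor), at 29 nM. Among the three numbers compound 3 stands second highest: compound 2 `CCCc1ccc(C(=O)Nc2cccc(NC(=O)COc3ccc4c(=O)ccoc4c3)c2)cc1` gives 14 nM, and compound 1 `CC(=O)Nc1cccc(NC(=O)COc2ccc3c(=O)ccoc3c2)c1` gives 136 nM. Compound 4 `Nc1ccc(C(=O)Nc2cccc(NC(=O)COc3ccc4c(=O)ccoc4c3)c2)cc1` differs from compound 3 by amino in place of methoxycarbonyl on an aromatic carbon. Among the compounds with values here, two measured steps bear on this change: a 4.7-fold lower number from compound 1 to compound 3 (0.67 log units; beyond the scatter), and a 2.1-fold higher number from compound 2 to compound 3 (0.32 log units; beyond the scatter). Both show that the group on the carbonyl carbon, and the substituent on the phenyl within it, move the number only modestly. Within the data shown here, no measured compound carries an amino group, so the direction is uncertain. Compound 4 is therefore expected to sit near compound 3, with a 1.0-fold higher number from compound 3 to compound 4 (0.01 log units; within the scatter) expected to stay within the scatter. The estimate for compound 4 is 30 nM, between 10 nM and 90 nM.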

Compound 4, half-maximal inhibitory concentration: 83 nM
Compound 4: the middle estimate sits 2.8-fold (0.44 log units) below what was measured, and the stated range covers the measured number.
By their numbers in this assay, from the lowest: compound 2; then compound 3; then compounds 4 and 1 (each within the scatter of the next).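

In this assay, within the data shown here, the substituent on this phenyl carries more weight than the earlier compounds showed: amino in place of methoxycarbonyl gives a clear loss (a 2.9-fold higher number from compound 3 to compound 4 (0.46 log units; beyond the scatter)), and amino in place of propyl gives a further one (a 5.9-fold higher number from compound 2 to compound 4 (0.77 log units; beyond the scatter)). The gain seen on replacing methyl with an aryl group therefore does not hold for 4-aminophenyl (a 1.6-fold lower number from compound 1 to compound 4 (0.21 log units; within the scatter)), which stays within the scatter. No evidence is available to explain these differences. From the compounds shown here alone, whether a carboxylic acid, a hydroxyl or a longer alkyl chain at this place would match propyl remains open.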